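The source may report more compounds than this note shows. Statements on the series, on what has been measured and on what is new or still open speak of the compounds shown alone.

Measured so far in an ADME assay for permeability, using PAMPA, with a stated time of 30 min, at pH 7.4; on this read-out lower numbers stand for lower permeability and higher numbers for higher permeability:
- compound 1, `c1ccc(-c2ccc3c(NCCCNCc4ccco4)ccnc3c2)cc1`: 237 10^-6 cm/s
- compound 2, `COc1cccc(Oc2ccc3c(NCCCNCc4cc(F)ccc4OC)ccnc3c2)c1`: 317 10^-6 cm/s
- compound 3, `COc1cccc(CNCCCNc2ccnc3cc(-c4ccc(C(F)(F)F)cc4)ccc23)c1O`: 237 10^-6 cm/s

Compound 1 stands level with compound 3 at the digits shown, the two together the lowest of the three numbers; compound 2 lies a little higher, but that gap is within the scatter, so nothing separates the three compounds in this assay.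

The next compound, compound 4, `COc1ccc(Oc2ccc3c(NCCCNCc4ccco4)ccnc3c2)cc1`, is not yet measured. It differs from compound 1 in one place: 4-methoxyphenoxy in place of phenyl on an aromatic carbon. For the measured compounds named here, no step of this kind is known here between measured compounds. Given that all three known values sit close together, the step from compound 1 to compound 4 is expected to stay within the scatter, perhaps leaning slightly upward, as a 1.1-fold higher number from compound 1 to compound 4 (0.04 log units; within the scatter). Compound 4 is therefore estimated at 260 10^-6 cm/s, between 160 10^-6 cm/s and 420 10^-6 cm/s.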

Compound 4, apparent permeability: 317 10^-6 cm/s
Compound 4: middle estimate off by 1.2-fold (0.09 log units), on the low side; the measured number falls inside the stated range.
By their numbers in this assay, from the lowest: compounds 1, 3, 2 and 4 (each within the scatter of the next).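

In this assay, for the compounds shown here, 4-methoxyphenoxy in place of phenyl on this aromatic carbon of the shared core gives a 1.3-fold higher number from compound 1 to compound 4 (0.13 log units; within the scatter), the only single-place comparison available. At this position, a group with 2 hydrogen-bond acceptors thus replaces one with 0 without a step beyond the scatter. No measurement at hand accounts for this step.

From the compounds shown here alone, whether an amine or a carboxylic acid at this position would give a step beyond the scatter remains open. The compounds shown also do not separate the ring oxygen from the methoxy group, as unsubstituted phenoxy is not among them.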